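A Second Trimethoxyphenyl Group: What Growth Inhibition May Show

The compounds below may be only part of what the source reports. "The series", "measured", "known", "first", "only" and "open" are said of these compounds alone.

Of the compounds shown here, two sharing one core have been measured in a functional assay on ACHN cells (Homo sapiens) for inhibition; a lower number here means a stronger inhibitor of growth, a higher number a weaker inhibitor of growth. Compound 1 `O=C(/C=C/c1cccc(O)c1)c1cccc(-n2cc(-c3ccccc3)[nH]c2=O)c1` gives 2760 nM, and compound 2 `COc1cc(/C=C/C(=O)c2cccc(-n3cc(-c4ccccc4)[nH]c3=O)c2)cc(OC)c1OC` gives 1600 nM. Compound 2 has the lower of the two numbers, but its gap to compound 1 lies within the usual scatter, so the two cannot be ranked. Compound 3 `COc1cc(/C=C/C(=O)c2cccc(-n3cc(-c4cc(OC)c(OC)c(OC)c4)[nH]c3=O)c2)cc(OC)c1OC` differs from compound 2 in one place: 3,4,5-trimethoxyphenyl in place of phenyl on an aromatic carbon. Among the measured compounds shown here, no step of this kind has been measured, so in this assay only a modest shift is expected, possibly none beyond the scatter. Compound 3 is expected to give 1200 nM, within 400 nM to 4000 nM. The expected step is a 1.3-fold lower number from compound 2 to compound 3 (0.12 log units; within the scatter).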

Compound 3, concentration for 50% growth inhibition: 1740 nM
The estimate for compound 3 lay 1.5-fold (0.16 log units) below the measured number; measured number inside the range.
By their numbers in this assay, from the lowest: compounds 2, 3 and 1 (each within the scatter of the next).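

In this assay, compound 3 shows a 1.1-fold higher number from compound 2 to compound 3 (0.04 log units; within the scatter) when 3,4,5-trimethoxyphenyl replaces phenyl on the aromatic carbon of the five-membered ring. This position therefore takes a much larger group, one with hydrogen-bond acceptors the phenyl lacks, without a change that can be read beyond the scatter. No measurement is available to explain this result.

As far as these compounds go, whether this position responds to any group at all remains open. An amine or a carboxylic acid on this phenyl ring could test that.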